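Ester in place of sulfonate: cytotoxicity kept at the limit

The source may report more compounds than this note shows. Statements on the series, on what has been measured and on what is new or still open speak of the compounds shown alone.

Compound 1 `CC(C)S(=O)(=O)OC1CCC(CN2CCN(c3cc(=O)c4cc(C(F)(F)F)cc([N+](=O)[O-])c4s3)CC2)CC1` was tested in an ADME assay on Vero cells (Chlorocebus sabaeus) for cytotoxicity, read by MTT assay, with a stated time of 48 h; a higher number here means a weaker inhibitor, a lower number a stronger inhibitor. In this assay compound 1 gives > 64 ug/mL, which is a limit of the assay. Two close relatives share its core. Compound 2 `O=C(OC1CCC(CN2CCN(c3cc(=O)c4cc(C(F)(F)F)cc([N+](=O)[O-])c4s3)CC2)CC1)c1ccco1` has (furan-2-yl)carbonyl in place of isopropylsulfonyl on an oxygen on a saturated carbon; in this assay compound 2 gives > 64 ug/mL, also a limit. Compound 3 `CS(=O)(=O)OC1CCC(CN2CCN(c3cc(=O)c4cc(C(F)(F)F)cc([N+](=O)[O-])c4s3)CC2)CC1` has methyl in place of isopropyl on a sulfonyl sulfur; in this assay compound 3 gives > 64 ug/mL, again a limit. The steps a step that the two limits leave unreadable from compound 1 to compound 2 and a step that the two limits leave unreadable from compound 1 to compound 3 therefore cannot be sized, and compound 1 stands with the other two at the limit of > 64 ug/mL in this assay, at which 3 of the 3 values shown sit.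

Compound 4 `COc1cccc(C(=O)OC2CCC(CN3CCN(c4cc(=O)c5cc(C(F)(F)F)cc([N+](=O)[O-])c5s4)CC3)CC2)c1` differs from compound 1 as follows: (3-methoxyphenyl)carbonyl in place of isopropylsulfonyl on an oxygen on a saturated carbon. The closest measured change, (furan-2-yl)carbonyl in place of isopropylsulfonyl from compound 1 to compound 2, stayed at the limit, so the step that the limit leaves unreadable from compound 1 to compound 4 is expected to be none beyond the scatter. Compound 4 is therefore expected to give 70 ug/mL, within a range from 30 ug/mL to 160 ug/mL, most probably reported once more as a limit.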

Compound 4, half-maximal inhibitory concentration: > 64 ug/mL
Compound 4 ended at the assay's limit; the forecaster's own chance of this, stated with the estimate: 80%; the middle value lies beyond the limit too.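

No step between compound 4 and compound 1, compound 2 or compound 3 can be read, because all four compounds stand at the same limit: the limit of > 64 ug/mL in this assay, at which 4 of the 4 values shown sit.

The compounds shown leave open how far these groups on the oxygen differ in this assay, since none gives an exact number.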